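Working notes: a fluoro step from compound 1

The source may hold more compounds than are shown below. What is called first, only, known or untested is meant among the compounds shown, and "the series" means these compounds.

Compound 1 `O=C(Nc1ccccc1)C(Cl)Cl`: 130000 nM
Compound 2 `Cc1cccc(NC(=O)C(Cl)Cl)c1`: 41100 nM

Both values come from a functional assay on A549 cells (Homo sapiens) for antiproliferative activity, read by MTT assay, with a stated time of 72 h; a lower number here means a stronger inhibitor, a higher number a weaker inhibitor. Compound 1 gives the higher of the two numbers at 130000 nM, which makes it the weaker inhibitor of the pair. Compound 3 `O=C(Nc1ccc(F)cc1)C(Cl)Cl` is the next to consider. Its change from the core of compound 1 is fluoro in place of hydrogen on an aromatic carbon. Among the compounds with values here, only one measured step bears on this: a 3.2-fold lower number from compound 1 to compound 2 (0.50 log units; beyond the scatter), a modest change with methyl in place of hydrogen on an aromatic carbon. It involves a different group and stands alone, so it is a loose guide. A step of similar or smaller size toward a lower number is expected in this assay. The estimated step is a 1.9-fold lower number from compound 1 to compound 3 (0.27 log units; within the scatter). For compound 3 the expected value is 70000 nM, with an estimated range from 30000 nM to 160000 nM.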

Compound 3, half-maximal inhibitory concentration: 68400 nM
Compound 3: the middle estimate sits 1.0-fold (0.01 log units) above what was measured; the range from low to high includes it.
By their numbers in this assay, from the lowest: compounds 2, 3 and 1 (each within the scatter of the next, the first and the last beyond it).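

In this assay, fluoro in place of hydrogen on an aromatic carbon, para to a group of 6 heavy atoms, gives a 1.9-fold lower number from compound 1 to compound 3 (0.28 log units; within the scatter), so at this position the replacement cannot be told apart from the hydrogen of compound 1. The methyl replacement, with a 3.2-fold lower number from compound 1 to compound 2 (0.50 log units; beyond the scatter), is the only single change shown here that lies beyond the scatter, but it differs from the fluoro change in both group and place, so the two steps do not separate the effect of one from the other. No measurement available here accounts for the size of the fluoro step.

The compounds shown leave open how an amine, a carboxylic acid or a longer alkyl chain would read at this position. Also open, from the compounds shown here alone, is whether methyl and fluoro would differ when placed on the same aromatic carbon.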